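Replacing one aryl group while keeping the phenoxy group

The source may hold more compounds than are shown below. What is called first, only, known or untested is meant among the compounds shown, and "the series" means these compounds.

Compound 1 `Cc1cccc(C2CC(c3ccc(Oc4ccccc4)cc3)=NN2c2ccc(S(N)(=O)=O)cc2)c1` carries a phenoxy group on its core. In an ADME assay on Vero 76 cells (Chlorocebus sabaeus) for cytotoxicity, read by MTT assay, with a stated time of 96 h (a higher number here means that more compound is tolerated, a lower number that less compound is tolerated), compound 1 gives 81000 nM. Compound 2 `NS(=O)(=O)c1ccc(N2N=C(c3ccc(OCc4ccccc4)cc3)CC2c2ccc(Cl)cc2)cc1` gives 82000 nM, within the scatter of compound 1, so the two stand together at the top of the three numbers. Compound 3 `Cc1cccc(C2CC(c3ccccc3)=NN2c2ccc(S(N)(=O)=O)cc2)c1` gives 25000 nM.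

Compound 4 `NS(=O)(=O)c1ccc(N2N=C(c3ccc(Oc4ccccc4)cc3)CC2c2ccccc2Cl)cc1` differs from compound 1 in one place: 2-chlorophenyl in place of 3-methylphenyl on a saturated ring carbon. In short, it has 2-chlorophenyl in place of 3-methylphenyl on a saturated ring carbon.

Among the measured compounds shown here, the one measured step is a 3.2-fold lower number from compound 1 to compound 3 (0.51 log units; beyond the scatter), with hydrogen in place of phenoxy on an aromatic carbon. That step is modest, and it concerns a group that compound 4 keeps, so it gives no size for the present change. For the measured compounds named here, no measured step exchanges the group on the saturated ring carbon. Compound 2 also holds a chlorophenyl group at that carbon, alongside a benzyloxy group, and its number cannot be told apart from that of compound 1. No step beyond the scatter is therefore expected in this assay. The expected change is a 1.2-fold lower number from compound 1 to compound 4 (0.06 log units; within the scatter). For compound 4 the estimated value is 70000 nM, with an expected range of 32000 nM to 100000 nM.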

Compound 4, half-maximal cytotoxic concentration: 29000 nM
Estimate against measurement, compound 4: 2.4-fold (0.38 log units) above, and the stated range ends above it.
By their numbers in this assay, from the lowest: compounds 3 and 4 (each within the scatter of the next); then compounds 1 and 2 (each within the scatter of the next).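

In this assay, among the compounds shown here, the exchange of 3-methylphenyl for 2-chlorophenyl on the saturated ring carbon gives a 2.8-fold lower number from compound 1 to compound 4 (0.45 log units; beyond the scatter), the first measured step at this position, and it shows that the number responds to the group held there. The two groups match in every count given, with 7 heavy atoms, one six-membered aromatic ring of carbon only and no hydrogen-bond donors or acceptors, so those counts do not separate them, and the change swaps the kind of substituent on the aryl ring and its place together. Nothing available gives a measured reason for the step, so its origin stays unexplained.

The compounds shown leave open whether the chlorine or its place on the aryl ring goes with the lower number, a question that 3-chlorophenyl or 2-methylphenyl on this carbon, with the phenoxy group kept, could settle. They also leave open how this position would respond to a group of another kind, such as a pyridyl ring or a morpholine.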